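The source may hold more compounds than are shown below. What is called first, only, known or untested is meant among the compounds shown, and "the series" means these compounds.

Compound 1 `OC[C@H]1O[C@@H](n2cnc3c(SC4CCCCC4)ncnc32)[C@H](O)[C@@H]1O` is the reference point here. In an assay on isolated protein for binding affinity to Equilibrative nucleoside transporter 1 (Homo sapiens) (a higher number here means a weaker inhibitor, a lower number a stronger inhibitor), compound 1 gives 6310 nM. Among the measured compounds shown here, compound 2 `Nc1nc(SCCc2ccccc2)c2ncn([C@@H]3O[C@H](CO)[C@@H](O)[C@H]3O)c2n1` is the only other measured compound, and in this assay compound 2 gives 16200 nM. Of these two numbers, compound 1 has the lower one, so it stands as the stronger inhibitor of the pair, and the gap to compound 2 is wider than the usual scatter of repeated measurements, so the order between the two can be trusted.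

The step of interest leads from compound 1 to compound 3 `OC[C@H]1O[C@@H](n2cnc3c(CSc4cccc(Cl)c4)ncnc32)[C@H](O)[C@@H]1O`. The two structures differ in one place (a group of 9 heavy atoms (7 carbon, 1 sulfur, 1 chlorine; one six-membered aromatic ring of carbon only) in place of a group of 7 heavy atoms (6 carbon, 1 sulfur; one six-membered non-aromatic ring of carbon only), on an aromatic carbon). For the measured compounds named here, no measured pair in this set shows the effect of such a change, so the expectation rests on compound 1 alone and on the size of the change itself. The step from compound 1 to compound 3 is expected to be modest and towards a lower number a 2.5-fold lower number from compound 1 to compound 3 (0.40 log units; beyond the scatter). Compound 3 is therefore estimated at 2500 nM in this assay, within a range from 600 nM to 10000 nM.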

Compound 3, half-maximal inhibitory concentration: 282 nM
The estimate for compound 3 lay 8.9-fold (0.95 log units) above the measured number; the whole stated range lies above it.
By their numbers in this assay, from the lowest: compound 3; then compound 1; then compound 2.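

In this assay, among the compounds shown here, putting the group of 9 heavy atoms in place of cyclohexylsulfanyl gives a 22-fold lower number from compound 1 to compound 3 (1.35 log units; beyond the scatter) and so provides the only step in this set, a large one that shows this aromatic carbon is a place where a single change can move the number strongly. The direction matters too: the group with the aromatic ring and the chlorine gives the stronger inhibitor, so the non-aromatic cyclohexylsulfanyl group is not required here for activity in this assay, and a group with more heavy atoms is accepted at this position. No supporting measurement is available to explain why the number falls.

The step changes several things at once, including the ring type, the chlorine and the carbon count, so the compounds shown leave open which of these carries the gain, and a plain phenyl group without the chlorine, or a fluorine or methoxy group in place of the chlorine, would help to separate them. Also open, as far as these compounds go, is how an amine or a longer chain on this same aromatic carbon would read in this assay when set against compound 3.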